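Amide variation on a weak piperazine series

This account rests on a few compounds, and the source may have more. Where it says the series, first, only, none or still open, it means among the compounds named here.

Compound 2 `CCCCCC(=O)c1ccc(OCCCN2CCN(C(=O)c3c[nH]cn3)CC2)cc1` is the higher of two numbers in an assay on isolated protein for binding affinity to histamine H2 receptor (Homo sapiens) (a higher number here means a weaker inhibitor, a lower number a stronger inhibitor), where compound 2 gives 19500 nM; compound 1 `CCCCCC(=O)c1ccc(OCCCN2CCNCC2)cc1` gives 14500 nM, and the step of a 1.3-fold higher number from compound 1 to compound 2 (0.13 log units; within the scatter) lies within the scatter. Compound 3 `CCCCCC(=O)c1ccc(OCCCN2CCN(C(=O)C(C)C)CC2)cc1` differs from compound 2 by isopropyl in place of 1H-imidazol-4-yl on a carbonyl carbon. Among the compounds with values here, only that one measured step bears on the amide position, and it was small, so compound 3 is expected to show no change beyond the scatter, a 1.1-fold lower number from compound 2 to compound 3 (0.06 log units; within the scatter). Compound 3 is therefore estimated at 17000 nM in this assay, with a range from 6000 nM to 50000 nM.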

Compound 3, inhibition constant: 29500 nM
Estimate against measurement, compound 3: 1.7-fold (0.24 log units) below; low and high end bracket the measured number.
By their numbers in this assay, from the lowest: compounds 1, 2 and 3 (each within the scatter of the next, the first and the last beyond it).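

In this assay, isopropyl in place of 1H-imidazol-4-yl on the carbonyl carbon gives a 1.5-fold higher number from compound 2 to compound 3 (0.18 log units; within the scatter) and so leaves this amide position without a change that stands clear of the scatter. Against the free amine nitrogen, however, isopropylcarbonyl gives a 2.0-fold higher number from compound 1 to compound 3 (0.31 log units; beyond the scatter) and thus the first step in the series to pass the scatter, if only modestly. Nothing available explains either step. Still open, on these data alone, is whether an amine or a carboxylic acid on the carbonyl carbon, or a longer chain, would give a stronger inhibitor than compound 1.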